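The source may hold more compounds than are shown below. What is called first, only, known or untested is meant among the compounds shown, and "the series" means these compounds.

Measured so far:
compound 1 `CC(C)(C)N(NC(=O)c1ccccc1)C(=O)c1ccccc1Br`: 170 nM
compound 2 `CC(C)(C)N(NC(=O)c1cccc(C#N)c1)C(=O)c1ccccc1Cl`: 955 nM

Both compounds were tested in an assay on cells for agonist activity at ecdysone receptor (Bombyx mori), read by a luciferase reporter, with a stated time of 24 h; a lower number here means that less compound is needed, a higher number that more compound is needed for the effect. Compound 1 gives 170 nM, and compound 2 gives 955 nM, the higher of the two numbers; the gap between them lies beyond the usual scatter, so compound 2 needs more compound for the same effect. The two differ in two places at once, so neither change can be credited alone.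

Compound 3 `Cc1cccc(C(=O)NN(C(=O)c2ccccc2Cl)C(C)(C)C)c1C` is not yet measured. It keeps the core and the 2-chlorophenyl side of compound 2 and changes one group: 2,3-dimethylphenyl in place of 3-cyanophenyl on a carbonyl carbon. Among the compounds with values here, with no single-change step between measured compounds to lean on, the expectation rests on compound 2 alone. The step of a 3.2-fold lower number from compound 2 to compound 3 (0.50 log units; beyond the scatter) in this assay is expected to run downward, beyond the scatter but modest. Compound 3 is expected to give 300 nM in this assay, within a range of 80 nM to 1200 nM.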

Compound 3, half-maximal effective concentration: 20 nM
Beside the measured number, compound 3's estimate is 15-fold (1.18 log units) above it; measured number below the stated range.
By their numbers in this assay, from the lowest: compound 3; then compound 1; then compound 2.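

In this assay, within the data shown here, the single change gives a 48-fold lower number from compound 2 to compound 3 (1.68 log units; beyond the scatter) while the core and the 2-chlorophenyl side stay the same, so the group on this carbonyl carbon can by itself shift the number by a large amount. Compound 1 and compound 2 could not show this, since they differ in two places at once. The data at hand give no measured reason why 2,3-dimethylphenyl gives the lower number.

On these data alone, the change removes the nitrile and adds two methyl groups in one move, so the share of each remains unknown, and a ring with a single methyl group would be needed to begin separating them. As far as these compounds go, how an amine or a methoxy group on this ring would behave also remains open, as does whether the same shift would appear with the 2-bromophenyl side of compound 1.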